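This account rests on a few compounds, and the source may have more. Where it says the series, first, only, none or still open, it means among the compounds named here.

Measured so far:
compound 1, `COc1ccc(F)cc1CNCCCNc1ccnc2cc(CCc3ccccc3)ccc12`: 23 10^-6 cm/s
compound 2, `CC(C)(C)c1ccc(-c2ccc3c(NCCCNCc4ccco4)ccnc3c2)cc1`: 237 10^-6 cm/s

Two compounds have been run in an ADME assay for permeability, using PAMPA, with a stated time of 30 min, at pH 7.4; a lower number here means that the compound crosses the layer more slowly, a higher number that the compound crosses the layer faster. Compound 1 gives 23 10^-6 cm/s and compound 2 gives 237 10^-6 cm/s; compound 2 thus holds the higher of the two numbers, and the gap to compound 1 lies beyond the scatter of repeated runs of this assay.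

Compound 3, `COc1ccc(F)cc1CNCCCNc1ccnc2cc(-c3ccc(C(C)(C)C)cc3)ccc12`, has not been measured. It differs from compound 2 in one place: 5-fluoro-2-methoxyphenyl in place of furan-2-yl on a saturated chain carbon bound to an amine nitrogen. The remainder of the molecule, including the 4-tert-butylphenyl group on the shared core, is unchanged.

Among the measured compounds shown here, no pair of measured compounds differing in exactly this way is available, so the size of the step cannot be read from the data. The expectation is for no step beyond the scatter, with a modest downward lean, so that the step from compound 2 to compound 3 in this assay is expected to be a 1.5-fold lower number from compound 2 to compound 3 (0.17 log units; within the scatter). Compound 3 is therefore estimated at 160 10^-6 cm/s in this assay, with a range from 60 10^-6 cm/s to 400 10^-6 cm/s.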

Compound 3, apparent permeability: 237 10^-6 cm/s
Compound 3: the middle estimate sits 1.5-fold (0.17 log units) below what was measured; the range from low to high includes it.
By their numbers in this assay, from the lowest: compound 1; then compounds 2 and 3 (each within the scatter of the next).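

In this assay, 5-fluoro-2-methoxyphenyl in place of furan-2-yl on a saturated chain carbon bound to an amine nitrogen leaves no change at the digits printed from compound 2 to compound 3 (within the scatter), so at this position 9 heavy atoms in place of 5 bring no step beyond the scatter. Among the compounds shown here, with the 5-fluoro-2-methoxybenzyl group held fixed, 4-(tert-butyl)phenyl in place of phenethyl on an aromatic carbon gives a 10-fold higher number from compound 1 to compound 3 (1.01 log units; beyond the scatter), the only step of the two that lies beyond the scatter. No measurement at hand gives a reason for either step.

Each step rests on a single pair, so neither can yet be called general across the series. Open, on these data alone, is whether a pyridine ring or a carboxylic acid on the same chain carbon, or a simple phenyl group on the aromatic carbon, would fit these two steps.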